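A few compounds are considered here, and "the series" means these few. Any claim that something is new, unique, unknown or untested is made for them only; others in the source may bear on it.

Measured compounds:
Compound 1, `COc1ccc(-c2cc(/C=C/C(=O)c3ccc(N)cc3)[nH]n2)cc1`, gives 96% in a functional assay on BT-549 cells (Homo sapiens) for cytotoxicity, read by sulforhodamine B assay, with a stated time of 48 h, tested at 0.1 uM; a lower number here means a stronger effect, a higher number a weaker effect of the compound at the concentration tested.
Compound 2, `COc1ccc(C(=O)/C=C/c2cc(-c3cc(OC)c(OC)c(OC)c3)n[nH]2)cc1OC`, gives 90% in this assay.
Compound 3, `COc1cc(-c2cc(/C=C/C(=O)c3ccc(F)c(F)c3)[nH]n2)cc(OC)c1OC`, gives 105% in this assay.

All three numbers sit close to the level of untreated cells, so none of these compounds does much at the concentration tested. Compound 1 stands second of the three, but its gap to compound 2 and its gap to compound 3 are both within the scatter, so no order among them can be read. For the measured compounds named here, the only step that can be computed in this assay is a number 15 percentage points higher from compound 2 to compound 3 (beyond the scatter), and it concerns the aryl ring on the carbonyl carbon, not the part of the molecule changed here.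

Compound 4, `COc1ccc(-c2cc(/C=C/C(=O)c3ccc(N)cc3)[nH]n2)cc1OC`, differs from compound 1 in one place: methoxy in place of hydrogen on an aromatic carbon. Compound 2 and compound 3 both carry a ring with three methoxy groups on the shared core, and compound 2 gives 90% while compound 3 gives 105%, so adding methoxy groups at that end has not moved the numbers far from the untreated level.

Going by the values given here, no measured step bears directly on this change, so the expectation rests on the narrow spread of all three numbers: the step of a number 2 percentage points lower from compound 1 to compound 4 (within the scatter) is expected to stay within the scatter. Compound 4 is therefore estimated at 94%, between 80% and 106%.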

Compound 4, a percentage reported as activity, at one concentration (the size of the read-out at that concentration, not a potency): 92%
Estimate against measurement, compound 4: 2 percentage points above, and the stated range covers the measured number.
By their numbers in this assay, from the lowest: compounds 2, 4, 1 and 3 (each within the scatter of the next, the first and the last beyond it).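

For the compounds shown here, putting methoxy in place of hydrogen on this aromatic carbon, ortho to a methoxy group, gives a number 4 percentage points lower from compound 1 to compound 4 (within the scatter) in this assay and is the first direct look at this position. Compound 1 and compound 4 differ only at this place, and at the one concentration tested, methoxy cannot be told apart from hydrogen there, whereas the earlier comparison among compounds 1, 2 and 3 could not isolate this position. No separate measurement bears on this result.

What the compounds shown leave open is whether another group at this position, such as a hydroxy group, a chlorine atom or a longer chain like ethoxy, would give a step beyond the scatter. As far as these compounds go, a reading at one concentration is also not a potency, so how compound 1 and compound 4 compare at higher concentrations stays open.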